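The source may hold more compounds than are shown below. What is called first, only, known or untested is meant among the compounds shown, and "the series" means these compounds.

Measured compounds in the series:

Compound 1 `Nc1ccc(-c2cc(=O)c3c(N)c(F)c(Cl)c(F)c3o2)cc1F`. In a functional assay on HeLa cells (Homo sapiens) for cytotoxicity, read by neutral red uptake, with a stated time of 3 days (a lower number here means a stronger inhibitor, a higher number a weaker inhibitor), compound 1 gives > 100000 nM, which is a limit of the assay and not a number.
Compound 2 `CN(C)c1c(F)c(N)c2c(=O)cc(-c3ccc(N)c(F)c3)oc2c1F`. In this assay compound 2 gives > 100000 nM, again a limit of the assay.
Compound 3 `CCOC(=O)c1c(F)c(N)c2c(=O)cc(-c3ccc(N)c(F)c3)oc2c1F`. In this assay compound 3 gives > 100000 nM, likewise a limit of the assay.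

Compound 3 therefore stands only at a limit, and the two other values shown are limits as well; all three sit at the limit of > 100000 nM in this assay, at which 3 of the 3 values shown sit. None of the three steps can be read: a step that the two limits leave unreadable from compound 1 to compound 2, a step that the two limits leave unreadable from compound 1 to compound 3 and a step that the two limits leave unreadable from compound 2 to compound 3 are all left unreadable by the limits on both sides, so no size or direction can be taken from them.

The next compound is compound 4 `COCc1c(F)c(N)c2c(=O)cc(-c3ccc(N)c(F)c3)oc2c1F`. It differs from compound 3 in one place: methoxymethyl in place of ethoxycarbonyl on an aromatic carbon. The measured steps bear on it only in that every change made so far at this aromatic carbon, from chloro to dimethylamino and to ethoxycarbonyl, has left the value at the limit.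

On that basis compound 4 is expected to give 150000 nM in this assay, with a range from 60000 nM to 500000 nM. The step from compound 3 to compound 4 is thus estimated as a step that the limit leaves unreadable from compound 3 to compound 4, most likely again reported only as a limit rather than a measured number.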

Compound 4, half-maximal inhibitory concentration: > 100000 nM
Compound 4 ended at the assay's limit; the forecaster's own chance of this, stated with the estimate: 85%; the middle value is on the limit's open side.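

Compound 4 gives > 100000 nM in this assay, a limit of the assay and not a number, so its steps from compound 1, compound 2 and compound 3 cannot be read: the limit of > 100000 nM in this assay, at which 4 of the 4 values shown sit.

The compounds shown leave open whether any group on this aromatic carbon gives a measurable value in this assay, and how far the four compounds differ.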